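The source may hold more compounds than are shown below. What is called first, only, known or untested is meant among the compounds shown, and "the series" means these compounds.

Compound 1 `O=C(Nc1ccc(C(=O)NO)cc1)Nc1ccc([N+](=O)[O-])cc1`: 28400 nM
Compound 2 `COc1ccc(NC(=O)Nc2ccc(/C=C/C(=O)NO)cc2)cc1`: 11900 nM

These numbers come from a functional assay on HCT-116 cells (Homo sapiens) for cytotoxicity, read by MTT assay, with a stated time of 72 h; a higher number here means a weaker inhibitor, a lower number a stronger inhibitor. Going by the values given here, of the two compounds measured so far, compound 2 has the lower number, at 11900 nM, and so is the stronger inhibitor. Its gap to compound 1 lies beyond the usual scatter.

Compound 3 `O=C(/C=C/c1ccc(NC(=O)Nc2ccc([N+](=O)[O-])cc2)cc1)NO` is the next step from compound 2. It keeps the rest of the structure but has nitro in place of methoxy on an aromatic carbon, para to a large group: nitro in place of methoxy on an aromatic carbon.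

Among the compounds with values here, no measured pair shows this change on its own. Compound 1 also carries a nitro group and gives 28400 nM, but a single compound cannot fix the size of the step. In this assay, a small rise in the number is therefore expected, probably not beyond the scatter. The expected change is a 1.3-fold higher number from compound 2 to compound 3 (0.10 log units; within the scatter). For compound 3, the estimated value is 15000 nM, with an expected range of 5000 nM to 40000 nM.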

Compound 3, half-maximal inhibitory concentration: 12600 nM
The estimate for compound 3 lay 1.2-fold (0.08 log units) above the measured number; measured number inside the range.
By their numbers in this assay, from the lowest: compounds 2 and 3 (each within the scatter of the next); then compound 1.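

In this assay, nitro in place of methoxy on an aromatic carbon, para to a large group, gives a 1.1-fold higher number from compound 2 to compound 3 (0.02 log units; within the scatter), so these two groups cannot be told apart at this position on the shared core. With the nitro group held constant, 2-(hydroxycarbamoyl)ethenyl in place of hydroxycarbamoyl on an aromatic carbon gives a 2.3-fold lower number from compound 1 to compound 3 (0.35 log units; beyond the scatter), a modest step but the only one of the two that clears the scatter. Nothing available explains either step.

On these data alone, only methoxy and nitro are compared at the para position, so it remains open whether an amine or a carboxylic acid there would shift the number. As far as these compounds go, it also remains open whether the same swap would stay within the scatter with hydroxycarbamoyl directly on the ring.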